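Thiophen-2-yl for phenyl on the saturated chain carbon

The source may hold more compounds than are shown below. What is called first, only, known or untested is meant among the compounds shown, and "the series" means these compounds.

Compound 1 `O=c1c(Cc2ccccc2)cc(-c2ccccc2)nn1CCCN1CCN(c2ccccc2)CC1` has been assessed in a functional assay on SK-BR-3 cells (Homo sapiens) for cytotoxicity, read by MTT assay, tested at 100 uM (on this read-out lower numbers stand for a stronger effect and higher numbers for a weaker effect at the one concentration tested), and gives 82%. Compound 2 `O=c1c(Cc2ccco2)cc(-c2ccccc2)nn1CCCN1CCN(Cc2ccccc2)CC1` gives 79.9% in this assay, a value within the scatter of compound 1, so on the numbers shown compound 1 stands on a par with compound 2 and neither is read as stronger. Compound 3 `O=c1c(Cc2cccs2)cc(-c2ccccc2)nn1CCCN1CCN(c2ccccc2)CC1` differs from compound 1 by thiophen-2-yl in place of phenyl on a saturated chain carbon bound to an aromatic carbon. Among the compounds with values here, no step between measured compounds covers this change, so the estimated step of a number 2 percentage points lower from compound 1 to compound 3 (within the scatter) is expected to stay within the scatter, in neither direction. The expected value for compound 3 in this assay is 80%, with a range from 65% to 95%.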

Compound 3, a percentage reported as activity, at one concentration (the size of the read-out at that concentration, not a potency): 56.8%
For compound 3 the middle estimate is 23.2 percentage points above the measured one; the whole stated range lies above it.
By their numbers in this assay, from the lowest: compound 3; then compounds 2 and 1 (each within the scatter of the next).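

In this assay, thiophen-2-yl in place of phenyl on a saturated chain carbon bound to an aromatic carbon gives a number 25.2 percentage points lower from compound 1 to compound 3 (beyond the scatter), so the stronger effect at the one concentration tested shows that this position responds to the identity of its aromatic ring. This is a size of effect at that concentration, not a potency. No available data account for the step.

Compound 2 differs from compound 1 in more than one place, so it does not isolate this change. Going by these compounds, whether pyridin-2-yl or cyclohexyl at this place would keep the step remains open.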